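Swapping the aryl group: from 2-methylphenyl to 3-iodophenyl

The source may hold more compounds than are shown below. What is called first, only, known or untested is meant among the compounds shown, and "the series" means these compounds.

Measured in a functional assay (muscle tissue) with Cavia porcellus as the target; a higher number here means that more compound is needed for the effect, a lower number that less compound is needed:
- compound 1 `COC(=O)C1=C(C)N=C(C)/C(=C(\O)OC)C1c1cccc(N(C)C)c1`: 891 nM
- compound 2 `COC(=O)C1=C(C)N=C(C)/C(=C(\O)OC)C1c1ccccc1C`: 6.03 nM

Of these two numbers, compound 2 has the lower, 6.03 nM, so less of it is needed for the effect than of compound 1. The next structure is compound 3 `COC(=O)C1=C(C)N=C(C)/C(=C(\O)OC)C1c1cccc(I)c1`, which has not yet been measured. The change is 3-iodophenyl in place of 2-methylphenyl on a saturated ring carbon. Among the compounds with values here, no measured pair tests this swap directly. Within the data shown here, the only guide is the wide gap between compound 1 at 891 nM and compound 2 at 6.03 nM, which shows that numbers in this assay can differ greatly across compounds sharing this core. The expected step of a 3.3-fold higher number from compound 2 to compound 3 (0.52 log units; beyond the scatter) is a modest rise in the number, just beyond the scatter. For compound 3 the estimated value is 20 nM, with an expected range from 5 nM to 80 nM.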

Compound 3, half-maximal effective concentration: 41.7 nM
Estimate against measurement, compound 3: 2.1-fold (0.32 log units) below; low and high end bracket the measured number.
By their numbers in this assay, from the lowest: compound 2; then compound 3; then compound 1.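

In this assay, the new step of a 6.9-fold higher number from compound 2 to compound 3 (0.84 log units; beyond the scatter) comes with 3-iodophenyl in place of 2-methylphenyl, so this swap on the saturated ring carbon moves the number beyond the scatter. Within the data shown here, the step of a 21-fold lower number from compound 1 to compound 3 (1.33 log units; beyond the scatter) gives the first direct comparison of two groups on the same aromatic carbon, and it shows that iodo in place of dimethylamino changes the number far more than the scatter allows. Nothing measured here explains either step.

The compounds shown leave open whether the gap between compound 2 and compound 3 follows the change of group or the change of its place on the aryl ring, a question that a methyl group in place of the iodo of compound 3 would help to settle. As far as these compounds go, how a carboxylic acid on that same aromatic carbon would fare also remains open.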